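Swapping the benzyl group on a compound at the limit

The source may report more compounds than this note shows. Statements on the series, on what has been measured and on what is new or still open speak of the compounds shown alone.

Compound 1 `OC[C@H]1O[C@@H](n2cnc3c(NCc4ccccc4F)ncnc32)[C@H](O)[C@@H]1O` - "not determined" (no result reported)
Compound 2 `COc1cccc(CNc2ncnc3c2ncn3[C@@H]2O[C@H](CO)[C@@H](O)[C@H]2O)c1` - "not determined" (no result reported)
Compound 3 `OC[C@H]1O[C@@H](n2cnc3c(NCc4ccc(F)c(Cl)c4)ncnc32)[C@H](O)[C@@H]1O` - > 166000 nM (a limit, not a number)

The read-out here is a functional assay on G-361 cells (Homo sapiens) for antiproliferative activity, with a stated time of 72 h (on this read-out lower numbers stand for stronger inhibition and higher numbers for weaker inhibition), and it gives very little to work from. Compound 1 and compound 2 have no result. Compound 3 is the only one with an entry, and that entry is a limit of the assay rather than a number: the limit of > 166000 nM in this assay, at which 1 of the 3 values shown sits, is all that is known of it.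

Compound 4 `Cc1ccc(O)c(CNc2ncnc3c2ncn3[C@@H]2O[C@H](CO)[C@@H](O)[C@H]2O)c1` has not yet been measured. It keeps the shared core and carries 2-hydroxy-5-methylphenyl in place of 3-chloro-4-fluorophenyl on a saturated chain carbon bound to a nitrogen on an aromatic ring as its one difference.

Going by the values given here, no pair of measured compounds shows what a change like this does, so any expectation is loose. A modest move towards stronger inhibition is expected, though another limit result would be no surprise. The estimated step is an at least 4.1-fold lower number from compound 3 to compound 4 (0.61 log units; beyond the scatter) and it carries wide uncertainty. For compound 4 the expected value is 40000 nM with an estimated range from 6000 nM to 166000 nM in this read-out.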

Compound 4, half-maximal inhibitory concentration: > 166000 nM
Compound 4 was reported as a limit (the forecaster's own chance of this, stated with the estimate: 45%); at least 4.1-fold (0.61 log units) between middle value and limit.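

No step from compound 3 to compound 4 can be read, since both entries are limits of the assay rather than numbers: the limit of > 166000 nM in this assay, at which 2 of the 4 values shown sit.

The compounds shown leave open whether 2-hydroxy-5-methylphenyl in place of 3-chloro-4-fluorophenyl changes inhibition at all.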